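Fluoro Analogue Tested for Cytotoxicity in Liver Cells

A few compounds are considered here, and "the series" means these few. Any claim that something is new, unique, unknown or untested is made for them only; others in the source may bear on it.

Compound 1 `NC(=O)c1nc(C#Cc2ccccc2)n(COCCO)n1` was examined in an ADME assay on Huh-5-2 cells (Homo sapiens) for cytotoxicity; on this read-out higher numbers stand for lower toxicity in this test and lower numbers for higher toxicity in this test. In this assay compound 1 gives > 50 ug/mL, which is a limit of the assay and not a number. Compound 2 `COc1ccc(C#Cc2nc(C(N)=O)nn2COCCO)cc1` gives > 50 ug/mL, again a limit. Compound 3 `NC(=O)c1nc(C#Cc2ccc(F)cc2)n(COCCO)n1` gives > 50 ug/mL, also a limit. Compound 1 thus stands at the limit of > 50 ug/mL in this assay, at which 3 of the 3 values shown sit, together with both other compounds. The steps a step that the two limits leave unreadable from compound 1 to compound 2 and a step that the two limits leave unreadable from compound 1 to compound 3 bear on the change to compound 4 `NC(=O)c1nc(C#Cc2ccccc2F)n(COCCO)n1`, in which (fluoro in place of hydrogen on an aromatic carbon); neither step has a readable size, so no direction can be drawn from them. Compound 4 is expected to sit at the same limit, and the step that the limit leaves unreadable from compound 1 to compound 4 is expected to be small. The estimate for compound 4 is 80 ug/mL, between 40 ug/mL and 200 ug/mL.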

Compound 4, half-maximal cytotoxic concentration: > 50 ug/mL
Compound 4 was reported as a limit (the forecaster's own chance of this, stated with the estimate: 85%); the middle value is on the limit's open side.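

Compound 4 gives only a limit in this assay, as do compound 1 and compound 3, so neither new step to compound 4 can be read: the limit of > 50 ug/mL in this assay, at which 4 of the 4 values shown sit. The compounds shown leave open whether any of them differs in cytotoxicity from the others.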